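Replacing a Urea Link by an Amide: Expected Cell Activity

This account rests on a few compounds, and the source may have more. Where it says the series, first, only, none or still open, it means among the compounds named here.

Of the compounds shown here, three have been measured in a functional assay on SF-539 cells (Homo sapiens) for inhibition, read by sulforhodamine B assay, with a stated time of 48 h, tested at 1 uM; on this read-out lower numbers stand for a stronger effect and higher numbers for a weaker effect at the one concentration tested. Compound 1 `O=C(Nc1cccc(-n2cc(-c3ccncc3)c(-c3cc(O)cc(Cl)c3)n2)c1)Nc1ccc(Cl)c(C(F)(F)F)c1` gives 91%. Compound 2 `COc1cc(Cl)cc(-c2nn(-c3cccc(NC(=O)Nc4ccc(Cl)c(C(F)(F)F)c4)c3)cc2-c2ccncc2)c1` gives 75%, and compound 3 `COc1cc(Cl)cc(-c2nn(-c3cccc(NC(=O)Nc4cc(C(F)(F)F)cc(C(F)(F)F)c4)c3)cc2-c2ccncc2)c1` gives 59%. Among the measured compounds shown here, the only single-point step measured, a number 16 percentage points lower from compound 1 to compound 2 (beyond the scatter), concerns a methyl in place of hydrogen on an oxygen on an aromatic ring. Compound 2 stands second highest of the three numbers, with compound 1 above it and compound 3 below it, both gaps beyond the scatter. Compound 4 `COc1cc(Cl)cc(-c2nn(-c3cccc(NC(=O)c4cccc(C(F)(F)F)c4)c3)cc2-c2ccncc2)c1` differs from compound 2 by 3-(trifluoromethyl)phenyl in place of (4-chloro-3-(trifluoromethyl)phenyl)amino on a carbonyl carbon. For the measured compounds named here, no measured step touches this part of the molecule, and the values of compounds 2 and 3 show only that altering the ring at this end shifts the read-out. The step is expected to be a modest weakening, a number 10 percentage points higher from compound 2 to compound 4 (within the scatter). Compound 4 is estimated at 85%, between 62% and 100%.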

Compound 4, a percentage reported as activity, at one concentration (the size of the read-out at that concentration, not a potency): 52%
The estimate for compound 4 lay 33 percentage points above the measured number, and the stated range ends above it.
By their numbers in this assay, from the lowest: compounds 4 and 3 (each within the scatter of the next); then compound 2; then compound 1.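

In this assay, putting 3-(trifluoromethyl)phenyl in place of (4-chloro-3-(trifluoromethyl)phenyl)amino on the carbonyl carbon gives a number 23 percentage points lower from compound 2 to compound 4 (beyond the scatter), so the effect at this position does not depend on keeping that amino nitrogen and its hydrogen-bond donor. The change removes the nitrogen and the chlorine together, so this step cannot separate the two. Nothing at hand offers an explanation for the size or direction of this step.

Going by these compounds, it remains open whether the nitrogen or the chlorine accounts for the step. On these data alone, it is also open how an amine or a longer alkyl chain in place of 3-(trifluoromethyl)phenyl on the carbonyl carbon would read out.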